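A few compounds are considered here, and "the series" means these few. Any claim that something is new, unique, unknown or untested is made for them only; others in the source may bear on it.

Compound 2, `CC(C)c1ccccc1NC(=O)N[C@H](C)c1ccccc1`, stands lowest of the three values obtained so far in an ADME assay on the whole organism with Oryza sativa as the target, tested at 10 uM; a higher number here means a weaker effect of the compound at the concentration tested, a lower number a stronger effect. In that assay compound 2 gives 17%, while compound 1, `CCc1cccc(NC(=O)N[C@@H](C)c2ccccc2)c1`, gives 86% and compound 3, `CC(C)c1ccccc1NC(=O)N[C@@H](C)c1ccccc1`, gives 93%. Among the compounds with values here, the one step that is a single change is the one between compounds 2 and 3: a number 76 percentage points higher from compound 2 to compound 3 (beyond the scatter). That step rests on (the fact that compounds 2 and 3 differ only in the configuration as drawn), the stereocentre alone setting the two apart.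

Compound 4, `C[C@@H](NC(=O)Nc1ccccc1I)c1ccccc1`, is reached from compound 2 by a single change at the aryl urea end: iodo in place of isopropyl on an aromatic carbon. Everything else, including the configuration as drawn at the stereocentre, is carried over from compound 2.

Within the data shown here, no measured step bears directly on this change; the only single step in hand concerns configuration, not the aryl substituent, and it was large. From the compounds shown here alone, with the stereocentre of compound 2 kept, compound 2 is the natural anchor, but the effect of iodo against isopropyl is untested here. Compound 4 is therefore expected to stay nearer the low end of the series, at an estimated 35%, within 10% to 75%. That expectation amounts to an estimated step of a number 18 percentage points higher from compound 2 to compound 4 (beyond the scatter).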

Compound 4, a percentage reported as activity, at one concentration (the size of the read-out at that concentration, not a potency): 96%
Estimate against measurement, compound 4: 61 percentage points below, and the stated range ends below it.
By their numbers in this assay, from the lowest: compound 2; then compounds 1, 3 and 4 (each within the scatter of the next).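

The low number of compound 2 turns out not to rest on its configuration alone. With the configuration as drawn carried over, iodo in place of isopropyl on this aromatic carbon gives a number 79 percentage points higher from compound 2 to compound 4 (beyond the scatter), so in this assay a single change at the aryl urea end removes the strong effect just as the change of configuration does, which gives a number 76 percentage points higher from compound 2 to compound 3 (beyond the scatter). Among compounds 2, 3 and 4, then, the low number is seen only where isopropyl and the configuration of compound 2 occur together, though nothing shown explains why iodo at this position has this effect.

The compounds shown leave open whether the low number of compound 2 depends on isopropyl in particular, or whether a methyl, a tert-butyl, a chloro or a methoxy group on the same aromatic carbon would keep it. They also leave open what iodo would give with the other configuration at the stereocentre, and what ethyl would give on this same aromatic carbon.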